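A few compounds are considered here, and "the series" means these few. Any claim that something is new, unique, unknown or untested is made for them only; others in the source may bear on it.

Measured so far:
compound 1 `Cc1ccc2[nH]c(C(=O)N[C@H]3CN(S(=O)(=O)c4ccccc4)C[C@@H]3C(=O)NCCN(C)C)cc2c1` — 93%
compound 2 `Cc1ccc2[nH]c(C(=O)N[C@H]3CN(S(=O)(=O)c4ccccc4)C[C@@H]3C(=O)NC[C@@H]3CCCN3C)cc2c1` — 87%
compound 3 `Cc1ccc2[nH]c(C(=O)N[C@H]3CN(S(=O)(=O)c4ccccc4)C[C@@H]3C(=O)N[C@@H]3CCCN(C)C3)cc2c1` — 91%

In a functional assay on HEK293 cells for agonist activity at growth hormone secretagogue receptor type 1 (Homo sapiens), read by HTRF and inositol phosphate accumulation, with a stated time of 90 min, in the presence of a further agent that is not named here (on this read-out higher numbers stand for larger maximal responses and lower numbers for smaller maximal responses), compound 3 gives 91%, the second highest of the three numbers. Its nearest neighbour is compound 1, with a number 2 percentage points lower from compound 1 to compound 3 (within the scatter); the furthest is compound 2, with a number 4 percentage points higher from compound 2 to compound 3 (within the scatter). The remaining measured step, a number 6 percentage points lower from compound 1 to compound 2 (within the scatter), is likewise within the scatter, so the three compounds cannot be ordered on this read-out.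

The next compound, compound 4 `Cc1ccc2[nH]c(C(=O)N[C@H]3CN(S(=O)(=O)c4ccccc4)C[C@@H]3C(=O)N[C@@H]3CCCNC3)cc2c1`, differs from compound 3 by hydrogen in place of methyl on an amine nitrogen in a ring. For the measured compounds named here, none of the measured steps changes the amine nitrogen in the ring directly; each of them exchanges the whole amine-bearing group on the amide-type nitrogen, and each stayed within the scatter. The measured steps therefore give no indication of any movement in this assay for a smaller change at the same end of the molecule, and no step beyond the scatter is expected from compound 3 to compound 4: the expected step is a number 2 percentage points lower from compound 3 to compound 4 (within the scatter). For compound 4 the estimate in this assay is 89%, with a range from 76% to 100%.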

Compound 4, largest response reached (Emax), in percent of the reference or control that the assay uses: 91%
The estimate for compound 4 lay 2 percentage points below the measured number; the range from low to high includes it.
By their numbers in this assay, from the lowest: compounds 2, 3, 4 and 1 (each within the scatter of the next).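

In this assay, for the compounds shown here, replacing the methyl on the amine nitrogen in the ring is the first change made directly at that atom, and it gives no change at the digits printed from compound 3 to compound 4 (within the scatter), so the piperidin-3-yl group holds the maximal response seen with 1-methylpiperidin-3-yl. Compound 4 also stays within the scatter of the two other amine-bearing groups, with a number 4 percentage points higher from compound 2 to compound 4 (within the scatter) and a number 2 percentage points lower from compound 1 to compound 4 (within the scatter), which means that, among these four compounds, the methyl on this nitrogen is not needed for a full-sized response on this read-out. No measurement on hand offers an explanation for this result.

The compounds shown leave open what an ethyl, acetyl or benzyl group on this ring nitrogen would give, and whether a carboxylic acid or a neutral amide in place of the amine would still keep the response in this assay. With all four numbers inside the scatter of one another, the maximal response alone does not separate these amine-bearing groups, and how the hydrogen and methyl compare on concentration needed for the response stays unresolved.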